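The source may hold more compounds than are shown below. What is called first, only, known or untested is meant among the compounds shown, and "the series" means these compounds.

Measured compounds:
compound 1 `C=CCOc1cc(/C=C/C(=O)c2ccc(OC)c3c2OC(C)(C)C=C3)ccc1OC` gives > 10000 nM in a functional assay on K562 cells (Homo sapiens) for cytotoxicity, read by MTT assay (on this read-out higher numbers stand for weaker inhibition and lower numbers for stronger inhibition), which is a limit of the assay rather than a number.
compound 2 `CCCCC(=O)Oc1cc(/C=C/C(=O)c2ccc(OC)c3c2OC(C)(C)C=C3)ccc1OC` gives 240 nM in this assay.
compound 3 `COc1ccc(/C=C/C(=O)c2ccc(OC)c3c2OC(C)(C)C=C3)cc1OC(=O)C(C)C` gives 570 nM in this assay.

Compound 1 thus stands at the limit of > 10000 nM in this assay, at which 1 of the 3 values shown sits, and carries no number of its own; it is the weakest point from which any step can be read. Compound 4 `COc1ccc(/C=C/C(=O)c2ccc(OC)c3c2OC(C)(C)C=C3)cc1OS(=O)(=O)c1ccc(C)cc1` differs from compound 1 by (4-methylphenyl)sulfonyl in place of allyl on an oxygen on an aromatic ring. The two steps that bear on this change replace the same allyl on the same oxygen: an at least 41-fold lower number from compound 1 to compound 2 (1.61 log units; beyond the scatter) and an at least 17-fold lower number from compound 1 to compound 3 (1.24 log units; beyond the scatter). Both are large and both run to lower numbers, though the group entering in compound 4 is (4-methylphenyl)sulfonyl rather than butylcarbonyl or isopropylcarbonyl, so their size is only a loose guide. A step to a lower number is expected, an at least 6.6-fold lower number from compound 1 to compound 4 (0.82 log units; beyond the scatter). Compound 4 is therefore estimated at 1500 nM, with a range from 300 nM to 8000 nM.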

Compound 4, half-maximal inhibitory concentration: 7850 nM
For compound 4 the middle estimate is 5.2-fold (0.72 log units) below the measured one; the measured number falls inside the stated range.
By their numbers in this assay, from the lowest: compound 2; then compound 3; then compound 4. At a limit, above all of these: compound 1.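

In this assay, the group on this oxygen on an aromatic ring sets the outcome over a wide span, and (4-methylphenyl)sulfonyl falls well short of both carbonyl groups: a 14-fold higher number from compound 3 to compound 4 (1.14 log units; beyond the scatter) and a 33-fold higher number from compound 2 to compound 4 (1.51 log units; beyond the scatter). Replacing allyl at this oxygen therefore does not by itself bring a low number, as the remaining change is only a floor within the scatter: an at least 1.2-fold lower number from compound 1 to compound 4 (0.10 log units; that floor lies within the scatter). That step can be read no further, since compound 1 holds a limit of the assay and not a number: the limit of > 10000 nM in this assay, at which 1 of the 4 values shown sits.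

As far as these compounds go, whether the weak result of compound 4 follows from the sulfonyl link or from the 4-methylphenyl ring stays open. Methanesulfonyl or benzoyl on the same oxygen would separate the two, and a longer acyl chain would show how far the butylcarbonyl result extends.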